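A Further Methoxy on Compound 3

The source may hold more compounds than are shown below. What is called first, only, known or untested is meant among the compounds shown, and "the series" means these compounds.

compound 1 `COc1ccccc1CNc1ncnc2c1ncn2C1CCCCO1`: > 100000 nM
compound 2 `COc1cccc(CNc2ncnc3c2ncn3C2CCCCO2)c1`: > 100000 nM
compound 3 `COc1ccc(CNc2ncnc3c2ncn3C2CCCCO2)cc1`: > 100000 nM

All three entries come from an ADME assay on BJ cells (Homo sapiens) for cytotoxicity, read by MTT assay, with a stated time of 72 h (on this read-out lower numbers stand for stronger inhibition and higher numbers for weaker inhibition), and each is a limit of the assay rather than a number. Compound 3 stands at > 100000 nM, which is a limit. Within the data shown here, it has no position of its own among its neighbours, and the series so far stands at the limit of > 100000 nM in this assay, at which 3 of the 3 values shown sit.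

Compound 4 `COc1ccc(CNc2ncnc3c2ncn3C2CCCCO2)cc1OC` differs from compound 3 in one place: methoxy in place of hydrogen on an aromatic carbon. In words, this is methoxy in place of hydrogen on an aromatic carbon.

The steps nearest to this change are a step that the two limits leave unreadable from compound 2 to compound 3 and a step that the two limits leave unreadable from compound 1 to compound 3, and the third is a step that the two limits leave unreadable from compound 1 to compound 2. Each of them exchanges one methoxyphenyl for another, and none adds a group. No measured size is therefore available to carry over, and no direction can be taken from them.

No readable step is expected in this assay, and compound 4 is expected to report the same limit. This expectation rests on compound 3 and its limit of > 100000 nM. The estimated step is a step that the limit leaves unreadable from compound 3 to compound 4. The estimate for compound 4 is 120000 nM, with an expected range from 50000 nM to 300000 nM.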

Compound 4, half-maximal inhibitory concentration: > 100000 nM
Compound 4 ended at the assay's limit (the forecaster's own chance of this, stated with the estimate: 85%); the middle value lies beyond the limit too.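

In this assay compound 4 gives > 100000 nM, which is a limit of the assay. No new step can be read from compound 2 or compound 3 to compound 4, and the series stands as follows: the limit of > 100000 nM in this assay, at which 4 of the 4 values shown sit.

The compounds shown leave open how far any of them lies beyond this limit, and which change would give a readable value in this assay.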